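The source may report more compounds than this note shows. Statements on the series, on what has been measured and on what is new or still open speak of the compounds shown alone.

In a functional assay on HeLa cells (Homo sapiens) for cytotoxicity, read by MTT assay (a higher number here means a weaker inhibitor, a lower number a stronger inhibitor), compound 1 (`CC(C)=CC[C@@H](OC[C@H](C)O)C1=CC(=O)c2c(O)ccc(O)c2C1=O`) gives 40300 nM, compound 2 (`CCCC(O)CC(=O)O[C@H](CC=C(C)C)C1=CC(=O)c2c(O)ccc(O)c2C1=O`) gives 59300 nM, and compound 3 (`CCCCC(O)CC(=O)O[C@H](CC=C(C)C)C1=CC(=O)c2c(O)ccc(O)c2C1=O`) gives 72200 nM. Compound 3 therefore sits with the other two, with no gap beyond the scatter: the data show a 1.2-fold higher number from compound 2 to compound 3 (0.09 log units; within the scatter) and a 1.8-fold higher number from compound 1 to compound 3 (0.25 log units; within the scatter). Compound 4 (`CCC(O)CO[C@H](CC=C(C)C)C1=CC(=O)c2c(O)ccc(O)c2C1=O`) has not yet been measured. It carries 2-hydroxybutyl in place of (2-hydroxyhexyl)carbonyl on an oxygen on a saturated carbon.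

The closest evidence comes from the exchanges starting at compound 1, which also carries a hydroxyalkyl group on that oxygen. Replacing its 2-hydroxypropyl gave a 1.5-fold higher number from compound 1 to compound 2 (0.17 log units; within the scatter), alongside the step to compound 3 already noted. Neither that exchange nor the chain difference between compound 2 and compound 3 left the scatter, so no clear shift is expected in this assay. The expected step is a 1.6-fold lower number from compound 3 to compound 4 (0.20 log units; within the scatter), which is estimated to stay within the scatter. For compound 4 the estimated value is 46000 nM, with an expected range of 23000 nM to 90000 nM.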

Compound 4, half-maximal inhibitory concentration: 28700 nM
Compound 4: middle estimate off by 1.6-fold (0.20 log units), on the high side; low and high end bracket the measured number.
By their numbers in this assay, from the lowest: compounds 4, 1, 2 and 3 (each within the scatter of the next, the first and the last beyond it).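

At the oxygen on a saturated carbon, the exchange of an acyl group for a hydroxyalkyl group now gives steps beyond the scatter in this assay: 2-hydroxybutyl in place of (2-hydroxyhexyl)carbonyl gives a modest shift (a 2.5-fold lower number from compound 3 to compound 4 (0.40 log units; beyond the scatter)), and 2-hydroxybutyl in place of (2-hydroxypentyl)carbonyl gives a similar one (a 2.1-fold lower number from compound 2 to compound 4 (0.32 log units; beyond the scatter)). Compound 1 and compound 4 both lack that carbonyl and stay together (a 1.4-fold lower number from compound 1 to compound 4 (0.15 log units; within the scatter)), so 1-hydroxypropyl in place of 1-hydroxyethyl moves nothing beyond the scatter. Nothing measured here explains the shift.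

The carbonyl and the chain length differ together in these exchanges, so the compounds shown leave open which of them goes with the shift. A 2-hydroxyhexyl group on that oxygen would separate the two, and an amine in place of the chain hydroxyl remains an open question as well.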